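The source may hold more compounds than are shown below. What is called first, only, known or untested is meant among the compounds shown, and "the series" means these compounds.

Two compounds share one core and differ only in the ring attached to the urea nitrogen. Compound 1 `COc1cc2cc(Oc3ccc(NC(=O)Nc4ccccc4)cc3)c(C)nc2cc1OC` carries a plain phenyl there, and in a functional assay on SF-268 cells (Homo sapiens) for inhibition, read by sulforhodamine B assay, with a stated time of 48 h, tested at 10 uM (a lower number here means a stronger effect, a higher number a weaker effect of the compound at the concentration tested), compound 1 gives 88.1%. Compound 2 `COc1cc2cc(Oc3ccc(NC(=O)Nc4ccc(Cl)c(C(F)(F)F)c4)cc3)c(C)nc2cc1OC` carries a 4-chloro-3-(trifluoromethyl)phenyl instead, and in this assay compound 2 gives -10.2%. Within the data shown here, on these two numbers compound 2 stands lowest, and the only measured step, a number 98.3 percentage points lower from compound 1 to compound 2 (beyond the scatter), is a large one that goes together with that single change of ring substituents. Compound 3 `COc1cc2cc(Oc3ccc(NC(=O)Nc4ccc(Cl)c(Cl)c4)cc3)c(C)nc2cc1OC` is not yet measured. It differs from compound 2 in one place: chloro in place of trifluoromethyl on an aromatic carbon. Among the measured compounds shown here, no measured step covers this swap, so the expectation rests on compound 2 alone, whose value of -10.2% marks a strong effect. The chloro already present remains, and a second chloro takes the spot of the trifluoromethyl. The step expected in this assay is therefore small, a number 18.2 percentage points higher from compound 2 to compound 3 (beyond the scatter), possibly within the scatter. Compound 3 is accordingly estimated at 8%, with a range from -15% to 45%.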

Compound 3, a percentage reported as activity, at one concentration (the size of the read-out at that concentration, not a potency): 43.7%
Compound 3: middle estimate off by 35.7 percentage points, on the low side, within the range that was stated.
By their numbers in this assay, from the lowest: compound 2; then compound 3; then compound 1.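

In this assay, chloro cannot stand in for trifluoromethyl at this place on the ring without a clear loss of effect: the swap gives a number 53.9 percentage points higher from compound 2 to compound 3 (beyond the scatter) even though the chloro group ortho to this place stays the same. The 3,4-dichlorophenyl ring still outperforms plain phenyl, with a number 44.4 percentage points lower from compound 1 to compound 3 (beyond the scatter) in this same read-out, so among these three compounds a strong effect does not depend entirely on trifluoromethyl, although the strongest effect here goes with that group. No measurement of any property of these groups accompanies the numbers.

Among these compounds, only two groups are compared at this place, so it remains open how a methyl, a methoxy or a nitrile would fall relative to trifluoromethyl and chloro, or what a bare hydrogen there would give with the other chloro kept. Each number also comes from one concentration, so these compounds leave open how the ranking would look across a range of concentrations.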